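Dropping One Chloro Group from a Dichlorobenzyl Oxime Ether

The source may report more compounds than this note shows. Statements on the series, on what has been measured and on what is new or still open speak of the compounds shown alone.

Measured so far:
compound 1 `Clc1ccc(CO/N=C/c2c(-c3ccc4ccccc4c3)nc3occn23)cc1Cl` — 370 nM
compound 2 `Clc1ccc(CO/N=C/c2c(-c3ccc(Br)cc3)nc3sccn23)cc1Cl` — 480 nM
compound 3 `Clc1ccc(CO/N=C/c2c(-c3ccc(-c4ccccc4)cc3)nc3sccn23)cc1Cl` — "not active" (no number reported)

Three compounds sharing a benzyl oxime ether attached to a fused bicyclic core were tested in an assay on HepG2 cells for agonist activity at nuclear receptor subfamily 1 group I member 3 (Homo sapiens), read by a luciferase reporter, with a stated time of 23 h; on this read-out lower numbers stand for an effect already at smaller amounts and higher numbers for an effect only at larger amounts of compound. In this assay compound 1 gives 370 nM, and compound 2 gives 480 nM; the gap between these two numbers lies within the usual scatter, so neither can be placed ahead of the other. Compound 3 carries a biphenyl where compound 2 carries a bromophenyl. In this assay compound 3 was reported as "not active" (no number reported) with no number attached.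

Compound 4 `Clc1ccc(CO/N=C/c2c(-c3ccc4ccccc4c3)nc3occn23)cc1` has not yet been measured in this assay. Compared with compound 1 it differs in one place: hydrogen in place of chloro on an aromatic carbon. For the measured compounds named here, no pair of measured compounds differing only at this position is available, so nothing in the present numbers fixes the size or the direction of such a step. The estimate therefore rests on compound 1 alone. The expected step is a modest loss, estimated as a 1.6-fold higher number from compound 1 to compound 4 (0.21 log units; within the scatter), with a wide range around it. Compound 4 is expected to give about 600 nM in this assay, between 250 nM and 1500 nM.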

Compound 4, half-maximal effective concentration: 990 nM
Beside the measured number, compound 4's estimate is 1.7-fold (0.22 log units) below it; the range from low to high includes it.
By their numbers in this assay, from the lowest: compounds 1 and 2 (each within the scatter of the next); then compound 4.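

Cutting 3,4-dichlorobenzyl back to 4-chlorobenzyl gives a 2.7-fold higher number from compound 1 to compound 4 (0.43 log units; beyond the scatter) in this assay and provides the first measured single-place step in this series, one that lies beyond the usual scatter. It shows that the chloro group on this aromatic carbon, ortho to a chloro group and meta to a large group, counts in this read-out, even though the change removes only one heavy atom and leaves the rest of compound 1 untouched. The loss is only partial, since compound 4 still gives 990 nM as a number rather than an entry without one, but no accompanying measurement accounts for the size of this step.

The compounds shown leave open whether a fluoro, methyl or methoxy group on the same carbon would give a number closer to that of compound 1 or to that of compound 4, and what removing the remaining chloro group of the 4-chlorobenzyl would do. They also leave open whether the same change would produce a step of similar size on the core of compound 2, which carries a bromophenyl in place of the naphthyl group.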